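Swapping the Terminal Amine on a Chemokine Receptor Antagonist

The source may hold more compounds than are shown below. What is called first, only, known or untested is meant among the compounds shown, and "the series" means these compounds.

Compound 1 `NCCCCN(C[C@H]1Cc2ccccc2CN1Cc1ccncc1)[C@H]1CCCc2cccnc21`: 660 nM
Compound 2 `CN(C)CCCCN(C[C@H]1Cc2ccccc2CN1)[C@H]1CCCc2cccnc21`: 8 nM

Both compounds were tested in a functional assay on Chem-1 cells for antagonist activity at C-X-C chemokine receptor type 4 (Homo sapiens), read by FLIPR and calcium flux, with a stated time of 10 min; on this read-out higher numbers stand for weaker inhibition and lower numbers for stronger inhibition. Compound 2 gives 8 nM, the lowest number of the two. Compound 1 gives 660 nM, a gap that lies well beyond the scatter of this assay. Within the data shown here, compound 1 differs from compound 2 in more than one place, so no single structural step links them; the two values show only that compound 2 is the stronger inhibitor of this pair.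

Compound 3 `CC(C)NCCCCN(C[C@H]1Cc2ccccc2CN1)[C@H]1CCCc2cccnc21` has not yet been measured. It is compound 2 with isopropylamino in place of dimethylamino on a saturated chain carbon, four bonds along the chain from an amine nitrogen. Among the measured compounds shown here, no measured pair shows what such an exchange does here, so the expectation rests on compound 2 alone. Because compound 2 gives 8 nM, compound 3 is expected to stay close to it, with a step of a 1.9-fold higher number from compound 2 to compound 3 (0.27 log units; within the scatter) that may not exceed the scatter. The estimate for compound 3 is 15 nM, within a range of 4 nM to 60 nM.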

Compound 3, half-maximal inhibitory concentration: 7 nM
Estimate against measurement, compound 3: 2.1-fold (0.33 log units) above, within the range that was stated.
By their numbers in this assay, from the lowest: compounds 3 and 2 (each within the scatter of the next); then compound 1.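

In this assay, isopropylamino in place of dimethylamino on a saturated chain carbon, four bonds along the chain from an amine nitrogen, gives a 1.1-fold lower number from compound 2 to compound 3 (0.06 log units; within the scatter), so the two compounds cannot be told apart and this position accepts the exchange. This holds although isopropylamino has 4 heavy atoms and 1 hydrogen-bond donor, where dimethylamino has 3 heavy atoms and 0 hydrogen-bond donors. No measurement shown explains why the two groups read alike.

Compound 1 carries a plain amine at the end of its chain but also differs from compound 2 in a further place, so it cannot show what a plain amine alone does on this core. Also open, going by these compounds, is whether the chain end needs an amine at all, which a hydroxyl group or a carboxylic acid there would test, and how a longer chain would read.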